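An Aminomethyl Group Added to the Most Lipophilic Amide

The source may hold more compounds than are shown below. What is called first, only, known or untested is meant among the compounds shown, and "the series" means these compounds.

Of the compounds shown here, three have been measured in a physicochemical assay for lipophilicity, read by HPLC, at pH 3.0; on this read-out lower numbers stand for lower lipophilicity and higher numbers for higher lipophilicity. Compound 1 `NCc1csc(NC(=O)c2cc3ccccc3n2Cc2ccccc2)n1` gives 2.4, compound 3 `NCc1csc(NC(=O)c2cn(Cc3ccccc3)nn2)n1` gives 1.1, and compound 2 `CC(C)(C)c1cc(C(=O)Nc2ccccc2)n(Cc2ccccc2)n1` gives 4.7, the highest of the three and beyond the scatter from both others. Compound 4 `CC(C)(C)c1cc(C(=O)Nc2cccc(CN)c2)n(Cc2ccccc2)n1` is not yet measured; it differs from compound 2 by aminomethyl in place of hydrogen on an aromatic carbon. Compound 1 already carries an aminomethyl group and sits at 2.4, as does compound 3 at 1.1, so the two lowest numbers belong to the aminomethyl-bearing compounds. A downward step well beyond the scatter is expected, estimated as a number 2.20 log units lower from compound 2 to compound 4 (beyond the scatter) in this assay. Compound 4 is expected to give about 2.5, with a likely range from 1.8 to 3.2.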

Compound 4, distribution coefficient: 2.2
Estimate against measurement, compound 4: 0.30 log units above; measured number inside the range.
By their numbers in this assay, from the lowest: compound 3; then compounds 4 and 1 (each within the scatter of the next); then compound 2.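

Among the compounds shown here, until now, no two measured compounds differed in only one place, so the share of aminomethyl in the low numbers could not be separated from differences in the rest of the structures. In this assay, for the compounds shown here, the single change from phenyl to 3-(aminomethyl)phenyl gives a number 2.50 log units lower from compound 2 to compound 4 (beyond the scatter) on its own. No measurement shown explains the size of this step.

A step of similar size with aminomethyl at another place on this ring remains an open question. So does the effect of a plain amine, aminoethyl or a carboxylic acid at this same position.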